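A few compounds are considered here, and "the series" means these few. Any claim that something is new, unique, unknown or untested is made for them only; others in the source may bear on it.

Compound 2 `CC1=CC[C@H]2[C@H](CC[C@]2(C)O)C(C)(C)[C@@H]1CC[C@H]1[C@]2(C)CC[C@H](OC(=O)NS(=O)(=O)c3ccc(C)cc3)C(C)(C)O[C@H]2CC[C@@]1(C)O` and compound 1 `CC(=O)O[C@H]1CC[C@]2(C)[C@H](CC[C@@](C)(O)[C@H]2CC[C@@H]2C(C)=CC[C@H]3[C@H](CC[C@]3(C)O)C2(C)C)OC1(C)C` share the same core and differ only in the group on a carbonyl carbon. In a functional assay on MDA-MB-231 cells (Homo sapiens) for antiproliferative activity, read by MTT assay, with a stated time of 72 h (on this read-out higher numbers stand for weaker inhibition and lower numbers for stronger inhibition), compound 2 gives 47100 nM, and in this assay compound 1 gives 38000 nM; the two numbers sit within the usual scatter of each other, so neither compound can be called the stronger inhibitor. Among the compounds with values here, the only measured step here is a 1.2-fold higher number from compound 1 to compound 2 (0.09 log units; within the scatter), and it shows that swapping the group on this carbonyl carbon barely moved the number.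

Compound 3 `CC1=CC[C@H]2[C@H](CC[C@]2(C)O)C(C)(C)[C@@H]1CC[C@H]1[C@]2(C)CC[C@H](OC(=O)c3cccc(C(F)(F)F)c3)C(C)(C)O[C@H]2CC[C@@]1(C)O` is the next compound. Its change from compound 2 is 3-(trifluoromethyl)phenyl in place of ((4-methylphenyl)sulfonyl)amino on a carbonyl carbon. Within the data shown here, the single measured step bears on this only loosely, as it involves a different entering group. Because of a 1.2-fold higher number from compound 1 to compound 2 (0.09 log units; within the scatter) the step is expected to be a 1.2-fold lower number from compound 2 to compound 3 (0.07 log units; within the scatter), again within the scatter. Compound 3 is therefore estimated at 40000 nM, with a range from 14000 nM to 110000 nM.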

Compound 3, half-maximal inhibitory concentration: 36300 nM
Estimate against measurement, compound 3: 1.1-fold (0.04 log units) above; low and high end bracket the measured number.
By their numbers in this assay, from the lowest: compounds 3, 1 and 2 (each within the scatter of the next).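

In this assay, putting 3-(trifluoromethyl)phenyl on the carbonyl carbon in place of ((4-methylphenyl)sulfonyl)amino gives a 1.3-fold lower number from compound 2 to compound 3 (0.11 log units; within the scatter), and putting it in place of methyl gives a 1.0-fold lower number from compound 1 to compound 3 (0.02 log units; within the scatter). Three quite different groups at this position, including one without the hydrogen-bond donor and acceptors counted for ((4-methylphenyl)sulfonyl)amino, therefore all give numbers within the scatter of each other, so this position shows no preference among them so far. No measured evidence is available to explain this.

On these data alone, whether a group carrying an amine or a carboxylic acid, or a longer alkyl chain, on this carbonyl carbon would separate from these three remains open. So does whether a change elsewhere on the shared core would shift the number beyond the scatter.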